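A few compounds are considered here, and "the series" means these few. Any claim that something is new, unique, unknown or untested is made for them only; others in the source may bear on it.

Measured so far in this series:
compound 1 `COc1ccccc1N1CCN(CC(O)CCn2cc(-c3ccc4ncccc4c3)nn2)CC1`, > 3000 nM
compound 2 `COc1ccccc1N1CCN(CC(O)CCn2cc(-c3ccc4ccccc4c3)nn2)CC1`, > 2000 nM
compound 3 `Clc1cccc(N2CCN(CCCCn3cc(-c4ccc5ccccc5c4)nn3)CC2)c1Cl`, > 1000 nM

In an assay on HEK293 cells for displacement of a labelled ligand from D(4) dopamine receptor (Homo sapiens), read by scintillation counting, with a stated time of 1 h (on this read-out higher numbers stand for weaker inhibition and lower numbers for stronger inhibition), none of the three readings is a number; each is a limit of the assay. Compound 1 sits at the limit of > 3000 nM in this assay, at which 1 of the 3 values shown sits. Compound 2 sits at the limit of > 2000 nM in this assay, at which 1 of the 3 values shown sits. Compound 3 sits at the limit of > 1000 nM in this assay, at which 1 of the 3 values shown sits. The change quinolin-6-yl in place of naphthalen-2-yl on an aromatic carbon therefore yields a step that the two limits leave unreadable from compound 2 to compound 1, and nothing about its direction or size can be taken from it. The difference between the core of compound 2 and the core of compound 3 is not broken down here.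

Compound 4 `Clc1cccc(N2CCN(CCCCn3cc(-c4ccc5ncccc5c4)nn3)CC2)c1Cl` has not been measured. It differs from compound 3 by quinolin-6-yl in place of naphthalen-2-yl on an aromatic carbon, the same change as from compound 2 to compound 1, at the same place. Because compound 3 reports only the limit > 1000 nM, and because the matching step from compound 2 to compound 1 was itself a step that the two limits leave unreadable from compound 2 to compound 1, no real guidance on size exists. For compound 4 the step that the limit leaves unreadable from compound 3 to compound 4 is expected, close to none. Compound 4 is estimated at 4000 nM, with a range of 1000 nM to 20000 nM, most likely again returned as a limit.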

Compound 4, inhibition constant: > 1000 nM
Compound 4 gave a limit, no number (the forecaster's own chance of this, stated with the estimate: 80%); the middle value lies beyond the limit too.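

In this assay compound 4 gives > 1000 nM, a limit of the assay and not a number. Compound 3 also stands at a limit, and no step can be read between compound 3 and compound 4. The compounds shown leave open how strongly any of them inhibits, and whether quinolin-6-yl in place of naphthalen-2-yl shifts the reading in either direction on either core.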